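The source may report more compounds than this note shows. Statements on the series, on what has been measured and on what is new or still open speak of the compounds shown alone.

Three compounds have been measured in a functional assay on HEK293 cells for agonist activity at Bombesin receptor subtype-3 (Homo sapiens), read by luminescence and calcium flux, with a stated time of 10 min; a higher number here means that more compound is needed for the effect, a lower number that less compound is needed:

compound 1 `CCC(C)(C)Cc1c[nH]c(CCc2ccc(-n3cccn3)cc2)n1`, 106 nM
compound 2 `CCC(C)(C)Cc1c[nH]c(CCc2ccc(-n3ncnn3)cc2)n1`, 89 nM
compound 3 `CCC(C)(C)Cc1c[nH]c(CCc2ccc(-c3cccc(N)n3)cc2)n1`, 97 nM

Compound 3 sits among the three numbers without separating from either neighbour: the step of a 1.1-fold higher number from compound 2 to compound 3 (0.04 log units; within the scatter) and the step of a 1.1-fold lower number from compound 1 to compound 3 (0.04 log units; within the scatter) both stay inside the scatter, so nothing can be said about an order among these compounds in this assay.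

Compound 4 `CCC(C)(C)Cc1c[nH]c(CCc2ccc(-n3cncn3)cc2)n1` has not yet been measured. It differs from compound 3 in one place: 1H-1,2,4-triazol-1-yl in place of 6-aminopyridin-2-yl on an aromatic carbon.

Two of the measured steps bear on this change. The step of a 1.2-fold lower number from compound 1 to compound 2 (0.08 log units; within the scatter) exchanged one five-membered ring bearing nitrogen for another on the same aromatic carbon and produced no movement beyond the scatter. The step of a 1.1-fold higher number from compound 2 to compound 3 (0.04 log units; within the scatter) replaced a five-membered ring with the six-membered ring that compound 4 now gives up, again with no movement beyond the scatter. For the measured compounds named here, every exchange at this position so far has left the number in this assay essentially unchanged, and a further five-membered ring bearing nitrogen is therefore expected to do the same.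

Compound 4 is thus estimated at 95 nM in this assay, with a range from 45 nM to 200 nM. The step from compound 3 that this estimate implies, a 1.0-fold lower number from compound 3 to compound 4 (0.01 log units; within the scatter), is expected to lie within the scatter.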

Compound 4, half-maximal effective concentration: 89 nM
Beside the measured number, compound 4's estimate is 1.1-fold (0.03 log units) above it; the range from low to high includes it.
By their numbers in this assay, from the lowest: compounds 2, 4, 3 and 1 (each within the scatter of the next).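

In this assay the exchange of 6-aminopyridin-2-yl for 1H-1,2,4-triazol-1-yl, on an aromatic carbon para to a large group, gives a 1.1-fold lower number from compound 3 to compound 4 (0.04 log units; within the scatter) and thus shows that this position tolerates a direct swap from the six-membered aromatic ring with its 1 hydrogen-bond donor to a five-membered aromatic ring with 0 hydrogen-bond donors and 3 hydrogen-bond acceptors. Set against the two other five-membered rings, the triazole gives no change at the digits printed from compound 2 to compound 4 (within the scatter) and a 1.2-fold lower number from compound 1 to compound 4 (0.08 log units; within the scatter) as well, so all four aromatic rings shown at this position now fall within the scatter of one another, and none of them stands apart from the rest. Nothing available explains why the number stays so flat across these exchanges.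

What remains open is whether any group at this position moves the number beyond the scatter, since every group shown is an aromatic ring, and a carboxylic acid, an open-chain amide or a plain hydrogen could behave differently. The compounds also share the rest of their structure, so they cannot say whether this insensitivity would hold on a core carrying a shorter or longer chain in place of the one they have.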